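Restoring the amide hydrogen in a long-chain anilide series

A few compounds are considered here, and "the series" means these few. Any claim that something is new, unique, unknown or untested is made for them only; others in the source may bear on it.

Compound 2 `CN(C(=O)CCCCCCCSc1nnc(Cc2nn(C)c(=O)c3ccccc23)n1C)c1ccc(Cl)cc1Cl`: 11900 nM
Compound 1 `CC(C)Oc1ccc(NC(=O)CCCCCCCSc2nnc(Cc3nn(C)c(=O)c4ccccc34)n2C)cc1`: 1100 nM

In an assay on isolated protein (Mus musculus) for inhibition of IL15-IL15 receptor (Homo sapiens), read by resazurin assay, with stated times of 30 min and 2.5 days (a lower number here means a stronger inhibitor, a higher number a weaker inhibitor), compound 2 stands highest of the two numbers shown; its nearest neighbour, compound 1, lies an 11-fold higher number from compound 1 to compound 2 (1.03 log units; beyond the scatter) away, the step consisting of a swap on the carbonyl carbon. Compound 3 `Cc1ccc(NC(=O)CCCCCCCSc2nnc(Cc3nn(C)c(=O)c4ccccc34)n2C)c(Cl)c1` is the untested analogue, differing from compound 2 by (2-chloro-4-methylphenyl)amino in place of (2,4-dichlorophenyl)(methyl)amino on a carbonyl carbon. Within the data shown here, the only step that bears on it is an 11-fold higher number from compound 1 to compound 2 (1.03 log units; beyond the scatter), where loss of the amide donor coincided with the large rise. Compound 3 brings the donor back, so in this assay a drop of about a 4.8-fold lower number from compound 2 to compound 3 (0.68 log units; beyond the scatter) is expected, and compound 3 is estimated at 2500 nM, within 800 nM to 8000 nM.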

Compound 3, half-maximal inhibitory concentration: 2300 nM
Beside the measured number, compound 3's estimate is 1.1-fold (0.04 log units) above it, within the range that was stated.
By their numbers in this assay, from the lowest: compound 1; then compound 3; then compound 2.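

In this assay, the amide with its hydrogen restored gives a 5.2-fold lower number from compound 2 to compound 3 (0.71 log units; beyond the scatter), although this single step also replaces a chlorine with a methyl, so the hydrogen's share cannot be separated. With the amide hydrogen present in both, the aryl group still matters, as changing it gives a 2.1-fold higher number from compound 1 to compound 3 (0.32 log units; beyond the scatter). Nothing available explains either step.

On these data alone, it remains open whether a 2,4-dichlorophenyl amide with its hydrogen would match compound 3. As far as these compounds go, how a carboxylic acid or an amine on the aryl ring, or a shorter chain, would read also remains open.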